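Methyl ethers of compound 1: notes on cell inhibition

The source may report more compounds than this note shows. Statements on the series, on what has been measured and on what is new or still open speak of the compounds shown alone.

Measured so far:
- compound 1 `O=C1C[C@H]2O[C@H]([C@H](O)c3ccccc3)[C@H](O)[C@H]2O1` gives 32500 nM in a functional assay on Jurkat cells (Homo sapiens) for inhibition, read by MTT assay, with a stated time of 72 h; on this read-out lower numbers stand for stronger inhibition and higher numbers for weaker inhibition
- compound 2 `CO[C@@H]1[C@H]2OC(=O)C[C@H]2O[C@@H]1[C@H](O)c1ccccc1` gives 24900 nM in this assay

Compound 1 holds the higher of the two numbers, but its gap to compound 2 is within the scatter. For the measured compounds named here, the one measured step, a 1.3-fold lower number from compound 1 to compound 2 (0.12 log units; within the scatter), is a methylation of a hydroxyl and carries no change beyond the scatter.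

Compound 3 `CO[C@H](c1ccccc1)[C@H]1O[C@@H]2CC(=O)O[C@@H]2[C@H]1O` differs from compound 1 by methyl in place of hydrogen on an oxygen on a saturated carbon. The same kind of change gave a 1.3-fold lower number from compound 1 to compound 2 (0.12 log units; within the scatter), so no step beyond the scatter is expected from compound 1 to compound 3 in this assay.

Compound 3 is therefore expected near 28000 nM, with a range of 12000 nM to 70000 nM. The expected step is a 1.2-fold lower number from compound 1 to compound 3 (0.06 log units; within the scatter).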

Compound 3, half-maximal inhibitory concentration: 15600 nM
Compound 3: the middle estimate sits 1.8-fold (0.25 log units) above what was measured; low and high end bracket the measured number.
By their numbers in this assay, from the lowest: compounds 3, 2 and 1 (each within the scatter of the next, the first and the last beyond it).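

In this assay the change from hydroxy to methoxy on this oxygen gives a 2.1-fold lower number from compound 1 to compound 3 (0.32 log units; beyond the scatter) and is modest, the first methylation in the series to pass the scatter. The other methylation, a 1.3-fold lower number from compound 1 to compound 2 (0.12 log units; within the scatter), stays within it, so the position of the methyl can matter, though only these two steps show this. No available evidence bears on the reason for this step.

Open, on these data alone, is whether an amine or a longer chain such as ethoxy at this place would move the number further. Also open, as far as these compounds go, is what methoxy on both oxygens together would give.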